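The source may report more compounds than this note shows. Statements on the series, on what has been measured and on what is new or still open speak of the compounds shown alone.

Compounds with measured numbers: compound 1 `C/C=C/C=C/C(=O)N[C@H](C(=O)NCCCCCCCC)[C@@H](C)O`, compound 2 `CCCCCCCCCCCCNC(=O)[C@@H](NC(=O)c1ccco1)[C@@H](C)O`, compound 3 `CCCCCCCCCCCCNC(=O)[C@@H](NC(=O)c1cc2ccccc2[nH]1)[C@@H](C)O`.

In a functional assay on MCF7 cells (Homo sapiens) for cytotoxicity, read by MTT assay, with a stated time of 48 h (on this read-out lower numbers stand for stronger inhibition and higher numbers for weaker inhibition), compound 1 gives 149000 nM. Compound 2 gives 67500 nM in this assay, and compound 3 gives 12300 nM, the lowest of the three numbers. For the measured compounds named here, the one step measured in one place is a 5.5-fold lower number from compound 2 to compound 3 (0.74 log units; beyond the scatter). Compound 4 `C/C=C/C=C/C(=O)N[C@H](C(=O)NCCCCCCCCCCCC)[C@@H](C)O` is not yet measured; it differs from compound 3 by penta-1,3-dien-1-yl in place of 1H-indol-2-yl on a carbonyl carbon. Going by the values given here, no measured step covers this exact exchange, but compound 1, which carries the same penta-1,3-dien-1-yl group on a shorter chain, sits far above compound 3. A clear step upward, to a higher number, is therefore expected, a 7.3-fold higher number from compound 3 to compound 4 (0.86 log units; beyond the scatter). Compound 4 is estimated at 90000 nM, with a range of 30000 nM to 250000 nM.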

Compound 4, half-maximal inhibitory concentration: 37100 nM
Estimate against measurement, compound 4: 2.4-fold (0.38 log units) above; measured number inside the range.
By their numbers in this assay, from the lowest: compound 3; then compounds 4 and 2 (each within the scatter of the next); then compound 1.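

In this assay an open chain on the carbonyl carbon keeps much of what 1H-indol-2-yl gives, with a 3.0-fold higher number from compound 3 to compound 4 (0.48 log units; beyond the scatter), and cannot be told apart from furan-2-yl, with a 1.8-fold lower number from compound 2 to compound 4 (0.26 log units; within the scatter). With penta-1,3-dien-1-yl held fixed, the chain on the other amide matters too: butyl in place of hydrogen gives a 4.0-fold lower number from compound 1 to compound 4 (0.60 log units; beyond the scatter). Nothing available explains either difference. Going by these compounds, whether a longer chain than in compound 4 would lower the number further stays open, and so does how a phenyl group would compare on the carbonyl carbon.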